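Amide nitrogen change from compound 2 to compound 4

A few compounds are considered here, and "the series" means these few. Any claim that something is new, unique, unknown or untested is made for them only; others in the source may bear on it.

Of the compounds shown here, three have been measured in an assay on brain with Translocator protein (Rattus norvegicus) as the target; on this read-out lower numbers stand for stronger inhibition and higher numbers for weaker inhibition. Compound 1 `CCN(CC)C(=O)c1cc(-c2ccccc2)c2ccccc2c1` gives 5 nM in this assay. Compound 2 `CCN(Cc1ccccc1)Cc1nc2ccccc2c(-c2ccccc2)c1C(=O)N(CC)CC` gives 373 nM in this assay, and compound 3 `CCOC(=O)c1c(N(CC)Cc2ccccc2)nc2ccccc2c1-c1ccccc1` gives 540 nM in this assay. Compound 2 stands second highest of the three numbers; its number and that of compound 3 lie within the scatter of each other, whereas the gap to compound 1 is well beyond the scatter, compound 1 showing the far lower number of the set. Going by the values given here, no pair of measured compounds differs in a single place, so no measured step is available to lean on.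

The unmeasured compound 4 `CCN(Cc1ccccc1)Cc1nc2ccccc2c(-c2ccccc2)c1C(=O)N(C)c1ccc(Cl)cc1` keeps the shared core of compound 2 and differs from it only at the amide: (4-chlorophenyl)(methyl)amino in place of diethylamino on a carbonyl carbon.

Among the compounds with values here, with no measured step resembling this change, the expectation rests on compound 2 alone. A step of modest size is expected in this assay, more likely toward a lower number than a higher one, though a result within the scatter of compound 2 would not surprise. Compound 4 is therefore estimated at 150 nM in this assay, with a range from 30 nM to 700 nM. The expected step reads a 2.5-fold lower number from compound 2 to compound 4 (0.40 log units; beyond the scatter) in this assay.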

Compound 4, half-maximal inhibitory concentration: 2480 nM
Beside the measured number, compound 4's estimate is 17-fold (1.22 log units) below it, and the stated range ends below it.
By their numbers in this assay, from the lowest: compound 1; then compounds 2 and 3 (each within the scatter of the next); then compound 4.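

The amide on the carbonyl carbon now has its first measured single-place step: (4-chlorophenyl)(methyl)amino in place of diethylamino gives a 6.6-fold higher number from compound 2 to compound 4 (0.82 log units; beyond the scatter) in this assay. Going by these compounds alone, this step lies beyond the scatter, so the number at this position depends on the amine part of the amide, which the earlier compounds could not show because no two of them differed in one place. Of the two groups tried here, diethylamino carries the lower number and the aromatic, chlorine-bearing replacement the higher one, but nothing available explains the direction or size of this step.

The change swaps several features at once, so the compounds shown leave open whether the higher number goes with the chlorine, the aromatic ring or the replacement of the two ethyl groups; methyl(phenyl)amino, dimethylamino and pyrrolidin-1-yl on the same carbonyl carbon would begin to separate these. Also open, on these data alone, is whether this amide change would bring a step of similar direction and size on the core of compound 1.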